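The source may hold more compounds than are shown below. What is called first, only, known or untested is meant among the compounds shown, and "the series" means these compounds.

Working notes on the series. Compound 1 `N[C@H]1CC[C@H](Nc2c(C(=O)NCc3ccc(F)cc3)nc(Br)c3cccnc23)CC1` is the measured anchor: in a functional assay on HCT-116 cells (Homo sapiens) for cytotoxicity, read by MTT assay, with a stated time of 72 h (a lower number here means a stronger inhibitor, a higher number a weaker inhibitor), compound 1 gives 7000 nM. Compound 2 `N[C@H]1CC[C@H](Nc2c(C(=O)NCc3cccs3)nc(Br)c3cccnc23)CC1` carries a (thiophen-2-yl)methyl on the amide-type nitrogen; in this assay compound 2 gives "not determined" (no result reported), so it stands nowhere on the measured numbers. Compound 3 `N[C@H]1CC[C@H](Nc2c(C(=O)Nc3ccccc3)nc(Br)c3cccnc23)CC1` differs from compound 2 in one place: phenyl in place of (thiophen-2-yl)methyl on an amide-type nitrogen. Among the compounds with values here, with no measured pair of this kind, the step in this assay is expected to stay within the scatter, in no definite direction. Compound 3 is estimated at 8000 nM, range 2000 nM to 30000 nM.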

Compound 3, half-maximal inhibitory concentration: 2000 nM
Compound 3: the middle estimate sits 4.0-fold (0.60 log units) above what was measured, and the stated range covers the measured number.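

In this assay, within the data shown here, the amide-type nitrogen proves sensitive to its substituent: phenyl in place of 4-fluorobenzyl gives a 3.5-fold lower number from compound 1 to compound 3 (0.54 log units; beyond the scatter) as the first measured step at this place. The step from compound 2 to compound 3 cannot be read, as compound 2 has no value. No evidence on the compounds bears on what lies behind the lower number.

Open, from the compounds shown here alone, is where unsubstituted benzyl would fall relative to compound 1 and compound 3. Also open, going by these compounds, is how a longer chain such as 2-phenylethyl, or a chain ending in an amine, would read on this nitrogen.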